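Sulfonamide series: cytotoxicity notes ahead of compound 4

The source may report more compounds than this note shows. Statements on the series, on what has been measured and on what is new or still open speak of the compounds shown alone.

Three measured compounds share a core bearing a sulfonyl group whose aryl part varies. Compound 1 `CC1CCN(C2CCN(S(=O)(=O)c3cccc(-c4ccc(F)cc4)c3)CC2)CC1` gives > 5000 nM in an ADME assay on HCT-116 cells (Homo sapiens) for cytotoxicity, read by CellTiter-Glo, with a stated time of 72 h (on this read-out higher numbers stand for weaker inhibition and lower numbers for stronger inhibition), a limit of the assay rather than a number. Compound 2 `CC1CCN(C2CCN(S(=O)(=O)c3ccc(C#N)cc3)CC2)CC1` gives > 5000 nM in this assay, again a limit. Compound 3 `CC1CCN(C2CCN(S(=O)(=O)c3nccn3C)CC2)CC1` gives > 10000 nM in this assay, also a limit. Compound 3 therefore has no readable position among the numbers shown: every value in the set is a limit, one sitting at the limit of > 10000 nM in this assay, at which 1 of the 3 values shown sits, and two at the limit of > 5000 nM in this assay, at which 2 of the 3 values shown sit. For the measured compounds named here, the only step between measured compounds is a step that the two limits leave unreadable from compound 2 to compound 3, and with both ends at limits its size cannot be read.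

Compound 4 `CC1CCN(C2CCN(S(=O)(=O)c3cccc(N)c3)CC2)CC1` differs from compound 3 by 3-aminophenyl in place of 1-methyl-1H-imidazol-2-yl on a sulfonyl sulfur. Going by the values given here, no measured step bears on this change with a readable size; the step from compound 2 to compound 3 is the nearest comparison, and it is unreadable. Nothing in the set points to inhibition strong enough to return a number, so compound 4 is expected to stay at the limit, and the estimated step of a number no higher from compound 3 to compound 4 (the limit leaves the size open) means no change beyond the scatter. The estimate for compound 4 in this assay is 10000 nM, ranging from 5000 nM to 30000 nM.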

Compound 4, half-maximal inhibitory concentration: > 5000 nM
Compound 4 was reported as a limit; the forecaster's own chance of this, stated with the estimate: 85%; the middle value lies beyond the limit too.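

In this assay compound 4 gives > 5000 nM, a limit of the assay. Compounds 1, 2 and 3 also stand at limits, so no new step can be read between compound 4 and any of them. The compounds shown leave open how the four compare in size and whether any group on the sulfonyl sulfur returns a number.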